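Decyl-triazole series: replacing the octyl tail with hydroxy

This account rests on a few compounds, and the source may have more. Where it says the series, first, only, none or still open, it means among the compounds named here.

Measured so far:
- compound 1 `O=C1O[C@H]([C@@H](O)Cn2cc(-c3cc(C(F)(F)F)cc(C(F)(F)F)c3)nn2)C(OCc2ccccc2)=C1OCc1ccccc1`: 28900 nM
- compound 2 `CCCCCCCCCCc1cn(C[C@H](O)[C@H]2OC(=O)C(OCc3ccccc3)=C2OCc2ccccc2)nn1`: 6750 nM
- compound 3 `O=C1O/C(=C\Cn2cc(-c3cccc(O)c3)nn2)C(OCc2ccccc2)=C1OCc1ccccc1`: 23300 nM

All three were run in a functional assay on A549 cells (Homo sapiens) for antiproliferative activity, read by MTT assay, with a stated time of 72 h; a lower number here means a stronger inhibitor, a higher number a weaker inhibitor. Compound 2 gives the lowest number of the three, with compound 3 and compound 1 both beyond the scatter above it, so compound 2 is the most potent of the set.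

Compound 4 `O=C1O[C@H]([C@@H](O)Cn2cc(CCO)nn2)C(OCc2ccccc2)=C1OCc1ccccc1` is not yet measured. It differs from compound 2 by hydroxy in place of octyl on a saturated chain carbon, two bonds along the chain from an aromatic carbon; read one bond further out, decyl becomes 2-hydroxyethyl. Among the compounds with values here, no pair measured so far differs in one place, so there is no step to lean on. The two compounds without a long chain, compound 1 and compound 3, both sit well above compound 2, and compound 4 is expected to follow them, with a step in this assay of a 5.9-fold higher number from compound 2 to compound 4 (0.77 log units; beyond the scatter) toward weaker inhibition. Compound 4 is estimated at 40000 nM, between 12000 nM and 130000 nM.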

Compound 4, half-maximal inhibitory concentration: > 100000 nM
Compound 4 was reported as a limit; the forecaster's own chance of this, stated with the estimate: 25%; middle value at least 2.5-fold (0.39 log units) away from the limit.
By their numbers in this assay, from the lowest: compound 2; then compounds 3 and 1 (each within the scatter of the next). At a limit, above all of these: compound 4.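

In this assay compound 4 gives > 100000 nM, which is a limit of the assay and not a number. Within the data shown here, the pair gives the first one-place step, and it is large: an at least 14-fold higher number from compound 2 to compound 4 (1.17 log units; beyond the scatter). At this position, decyl cannot be exchanged for 2-hydroxyethyl without a large loss of activity, and the full size of that loss stays unread: the limit of > 100000 nM in this assay, at which 1 of the 4 values shown sits.

The compounds shown leave open whether the loss goes with the shorter chain or with the hydroxy, which a plain ethyl group or a decyl chain ending in hydroxy would separate. Also open, as far as these compounds go, is how a chain longer than decyl, or one ending in an amine, behaves here.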